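Swapping isopentyl for 2-phenylethenyl on an amine chain

This account rests on a few compounds, and the source may have more. Where it says the series, first, only, none or still open, it means among the compounds named here.

Results so far in a functional assay on HL-60 cells (Homo sapiens) for inhibition (a higher number here means a weaker inhibitor, a lower number a stronger inhibitor), are these

Compound 1 `CN1CCC=C(c2ccc(CN(C)C/C=C/c3ccccc3)cc2)C1` – 680 nM
Compound 2 `CC(C)CCN(C)Cc1ccc(C2CCCN(C)C2)cc1` – "not determined" (no result reported)
Compound 3 `CC(C)CCCN(C)Cc1ccc(C2CCCN(C)C2)cc1` – "not determined" (no result reported)

Compound 3 has no place on the potency scale yet: the entry for compound 3 reads "not determined" (no result reported) and gives no number, as does the entry for compound 2. Compound 4 `CN(C/C=C/c1ccccc1)Cc1ccc(C2CCCN(C)C2)cc1` has not yet been measured. The structural step is 2-phenylethenyl in place of isopentyl on a saturated chain carbon bound to an amine nitrogen and in plain words it puts 2-phenylethenyl in place of isopentyl on a saturated chain carbon bound to an amine nitrogen.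

Without a number for compound 3, this step cannot be sized from data. A moderate move toward stronger inhibition in this assay is still expected. Going by the values given here, this rests on thin evidence: compound 1 (680 nM) is the only compound with a number, and it also carries 2-phenylethenyl. Compound 4 is therefore estimated at 650 nM with an expected range from 200 nM to 2200 nM on this read-out.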

Compound 4, half-maximal inhibitory concentration: 1100 nM
Beside the measured number, compound 4's estimate is 1.7-fold (0.23 log units) below it; low and high end bracket the measured number.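

With the 2-phenylethenyl group on a saturated chain carbon bound to an amine nitrogen, this assay now has a number for the core that compound 2 and compound 3 also carry: compound 4 gives 1100 nM on this read-out. Set against compound 1, which has the same chain, the result is a 1.6-fold higher number from compound 1 to compound 4 (0.21 log units; within the scatter) and so shows that exchanging one six-membered non-aromatic ring with a hetero atom for the other, on an aromatic carbon, cannot be told from scatter here. The step from compound 3 to compound 4 cannot be read, as compound 3 has no number.

Going by these compounds, whether a benzyl or cyclohexyl group at this chain position would read differently from 2-phenylethenyl remains open. No available evidence explains these results.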